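The source may report more compounds than this note shows. Statements on the series, on what has been measured and on what is new or still open speak of the compounds shown alone.

Measured in an ADME assay on Caecum (Rattus norvegicus, strain Sprague-Dawley) for metabolic stability, read by LC-MS, tested at 10 uM; on this read-out lower numbers stand for a shorter-lived compound and higher numbers for a longer-lived compound:
Compound 1 `C[C@@H](N[C@H]1CCN(c2ccc(S(=O)(=O)NC(=O)CCC(=O)O)cc2)C1)c1cccc2ccccc12`: 10.5 h
Compound 2 `C[C@@H](N[C@H]1CCN(c2ccc(C(=O)NC(CO)(CO)CO)cc2)C1)c1cccc2ccccc12`: > 12 h, a limit of the assay
Compound 3 `C[C@@H](N[C@H]1CCN(c2ccc(C(=O)NCCCCNC(CO)(CO)CO)cc2)C1)c1cccc2ccccc12`: 8 h

Compound 3 gives 8 h, which lies within the scatter of compound 1 at 10.5 h. The value of compound 2, > 12 h, is a limit.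

Compound 4 `C[C@@H](N[C@H]1CCN(c2ccc(C(=O)NCCS(=O)(=O)O)cc2)C1)c1cccc2ccccc12` is still unmeasured and differs from compound 3 as follows: sulfo in place of 2-((2-hydroxy-1,1-bis(hydroxymethyl)ethyl)amino)ethyl on a saturated chain carbon, two bonds along the chain from an amide-type nitrogen. It carries sulfo in place of 2-((2-hydroxy-1,1-bis(hydroxymethyl)ethyl)amino)ethyl on a saturated chain carbon, two bonds along the chain from an amide-type nitrogen.

Going by the values given here, two measured steps bear on this change. The closer one, an at least 1.5-fold lower number from compound 2 to compound 3 (0.17 log units; that floor lies within the scatter), exchanged the group on an amide-type nitrogen. The other, an at least 1.1-fold higher number from compound 1 to compound 2 (0.05 log units; that floor lies within the scatter), exchanged a group on an aromatic carbon. Neither floor goes beyond the scatter, so no step beyond the scatter is expected in this assay, although the change itself is a large one and the measured steps offer only a loose guide to it.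

The expected change is a 1.3-fold higher number from compound 3 to compound 4 (0.10 log units; within the scatter), which stays within the scatter. Compound 4 is estimated at 10 h, with an expected range from 6 h to 15 h.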

Compound 4, half-life: 0.8 h
Estimate against measurement, compound 4: 13-fold (1.10 log units) above, outside the stated range (below it).
By their numbers in this assay, from the lowest: compound 4; then compounds 3 and 1 (each within the scatter of the next). At a limit, above all of these: compound 2.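

In this assay, going by these compounds alone, the only change at this position that clearly shortens the half-life is the one that puts sulfo on the saturated chain carbon, two bonds along the chain from an amide-type nitrogen, in place of 2-((2-hydroxy-1,1-bis(hydroxymethyl)ethyl)amino)ethyl: a 10-fold lower number from compound 3 to compound 4 (1.00 log units; beyond the scatter). The fall is not specific to that one comparison, as (2-sulfoethyl)carbamoyl in place of ((2-carboxyethyl)carbonyl)sulfamoyl on an aromatic carbon also gives a step beyond the scatter, a 13-fold lower number from compound 1 to compound 4 (1.12 log units; beyond the scatter). The third comparison, an at least 15-fold lower number from compound 2 to compound 4 (1.17 log units; beyond the scatter), starts from a limit of the assay and so gives only a floor: the limit of > 12 h in this assay, at which 1 of the 4 values shown sits.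

Going by these compounds, compound 4 alone carries the 2-sulfoethyl group, so it remains open whether the short half-life follows from the sulfo group itself or from the chain that bears it; a carboxylic acid or an amine on the same two-carbon chain, or sulfo on a longer chain, would separate the two. The compounds shown also do not reveal what becomes of compound 4 in this assay, as the read-out gives its half-life and no products.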